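The compounds below may be only part of what the source reports. "The series", "measured", "known", "first", "only" and "open" are said of these compounds alone.

Compound 3 `C=CCn1c(=O)/c(=C\c2cc(F)ccc2C)[nH]c(=O)/c1=C\c1ccccc1OC` gives 1600 nM in a functional assay on BGC-823 cells (Homo sapiens) for cytotoxicity, read by CCK-8 assay, with a stated time of 72 h (on this read-out lower numbers stand for stronger inhibition and higher numbers for weaker inhibition), the lowest of the two numbers in hand. Among the measured compounds shown here, its nearest neighbour is compound 1 `C=CCn1c(=O)/c(=C\c2cccc(C)c2)[nH]c(=O)/c1=C\c1ccccc1OC`, which in this assay gives 20400 nM; the only single-point step in the set, a 13-fold lower number from compound 1 to compound 3 (1.11 log units; beyond the scatter), separates the two. Compound 2 `C=CCn1c(=O)/c(=C\c2ccc(Cl)c(Cl)c2)[nH]c(=O)/c1=C\c1ccccc1` is reported in this assay as "not active" (no number reported), without a number. Compound 4 `C=CCn1c(=O)/c(=C\c2cccc(Cl)c2)[nH]c(=O)/c1=C\c1ccccc1OC` is next: 3-chlorophenyl in place of 5-fluoro-2-methylphenyl on a double-bonded chain carbon bound to an aromatic carbon. For the measured compounds named here, the one measured step that bears on this change is a 13-fold lower number from compound 1 to compound 3 (1.11 log units; beyond the scatter), which runs through the same place and was large. The 3-chlorophenyl of compound 4 resembles the 3-methylphenyl of compound 1 more than the 5-fluoro-2-methylphenyl of compound 3, so the expectation is a step back toward the number of compound 1, though not necessarily all the way, since a single step is a thin basis. For compound 4 the estimate in this assay is therefore 8000 nM, within 2500 nM to 25000 nM, and the step of a 5.0-fold higher number from compound 3 to compound 4 (0.70 log units; beyond the scatter) is expected to lie beyond the scatter.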

Compound 4, half-maximal inhibitory concentration: 4600 nM
Compound 4: middle estimate off by 1.7-fold (0.24 log units), on the high side; the measured number falls inside the stated range.
By their numbers in this assay, from the lowest: compound 3; then compound 4; then compound 1.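

Chloro in place of methyl on an aromatic carbon gives a 4.4-fold lower number from compound 1 to compound 4 (0.65 log units; beyond the scatter) in this assay, so the number at this place moves with one substituent alone and not only with the full change to 5-fluoro-2-methylphenyl. Yet 3-chlorophenyl in place of 5-fluoro-2-methylphenyl gives a 2.9-fold higher number from compound 3 to compound 4 (0.46 log units; beyond the scatter), so chloro recovers only part of the gap and compound 3 keeps the lowest number of the three. No evidence on the cause of either step is in hand.

The compounds shown do not separate the share of the fluoro from that of the methyl in the number of compound 3. As far as these compounds go, it also remains open how this place would respond to a group such as a nitrile or an amine on the same aromatic ring.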